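This account rests on a few compounds, and the source may have more. Where it says the series, first, only, none or still open, it means among the compounds named here.

Measured in a functional assay on PC-3 cells (Homo sapiens) for antiproliferative activity, read by MTT assay, with a stated time of 24 h; on this read-out lower numbers stand for stronger inhibition and higher numbers for weaker inhibition:
- compound 1 `CCn1c(C(=O)N[C@H](C)C(=O)OC)ccc1C(CC)(CC)c1ccc(OCS(=O)(=O)c2ccccc2)c(C)c1`: > 50000 nM (a limit)
- compound 2 `CCn1c(C(=O)N[C@@H](CC(=O)OC)C(=O)OC)ccc1C(CC)(CC)c1ccc(OCS(=O)(=O)c2ccccc2)c(C)c1`: 6490 nM
- compound 3 `CCn1c(C(=O)NCCNC(=O)OC(C)(C)C)ccc1C(CC)(CC)c1ccc(OCS(=O)(=O)c2ccccc2)c(C)c1`: > 50000 nM (a limit)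

Compound 3 gives only a limit and stands at the limit of > 50000 nM in this assay, at which 2 of the 3 values shown sit. Compound 4 `CCn1c(C(=O)NCCN)ccc1C(CC)(CC)c1ccc(OCS(=O)(=O)c2ccccc2)c(C)c1` carries hydrogen in place of tert-butoxycarbonyl on an amine nitrogen.

The closest evidence comes from changes to the substituent on the amide nitrogen: an at least 7.7-fold lower number from compound 1 to compound 2 (0.88 log units; beyond the scatter) and an at least 7.7-fold higher number from compound 2 to compound 3 (0.88 log units; beyond the scatter). Both lie beyond the scatter, whereas a step that the two limits leave unreadable from compound 1 to compound 3 gives no size. Neither readable step removes tert-butoxycarbonyl, so they guide only loosely. A step of similar size towards a lower number is expected, although a further limit remains possible. The expected change is an at least 3.3-fold lower number from compound 3 to compound 4 (0.52 log units; beyond the scatter). For compound 4 the estimate is 15000 nM, with an expected range of 3000 nM to 50000 nM.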

Compound 4, half-maximal inhibitory concentration: 6890 nM
For compound 4 the middle estimate is 2.2-fold (0.34 log units) above the measured one; measured number inside the range.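

In this assay, hydrogen in place of tert-butoxycarbonyl on the amine nitrogen gives an at least 7.2-fold lower number from compound 3 to compound 4 (0.86 log units; beyond the scatter), and the 2-aminoethyl group also gives an at least 7.2-fold lower number from compound 1 to compound 4 (0.86 log units; beyond the scatter). With 2-aminoethyl in place of 1,2-bis(methoxycarbonyl)ethyl on the amide-type nitrogen, the result is a 1.1-fold higher number from compound 2 to compound 4 (0.03 log units; within the scatter), so two quite different substituents now read alike. Compound 1 and compound 3 each stand at a limit, not a number: the limit of > 50000 nM in this assay, at which 2 of the 4 values shown sit.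

On these data alone, whether the free amine itself matters, or only the loss of tert-butoxycarbonyl, stays open. A longer chain ending in an amine, or a carboxylic acid on the same chain, would bear on this.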